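Stereocentre inversion from compound 3 to compound 4

The compounds below may be only part of what the source reports. "The series", "measured", "known", "first", "only" and "open" are said of these compounds alone.

In a physicochemical assay for solubility, read by HPLC, in phosphate buffer, at pH 6.5 (on this read-out higher numbers stand for higher solubility and lower numbers for lower solubility), compound 1 (`COC(=O)C1=C(C)NC(c2nccs2)=NC1(C)c1ccc(OC)cc1`) gives 106 ug/mL in these notes, and compound 2 (`COC(=O)C1=C(CN2CCC(O)CC2)NC(c2nccs2)=NC1(C)c1ccc(F)cc1`) gives 593 ug/mL on the same read-out. Compound 3 (`COC(=O)C1=C(CN2CCC[C@@H]2C(=O)O)NC(c2nccs2)=N[C@@]1(C)c1ccc(F)cc1`) has no number, only a limit of the assay, reported as > 659 ug/mL for this compound. Compound 4 (`COC(=O)C1=C(CN2CCC[C@H]2C(=O)O)NC(c2nccs2)=N[C@@]1(C)c1ccc(F)cc1`) follows from compound 3 through one change (the two compounds have the same atoms and bonds and differ only in configuration as drawn: 1 of 2 stereo elements differ; a stereocentre at a saturated ring carbon is drawn R in compound 3 and S in compound 4): a stereocentre at a saturated ring carbon is drawn R in compound 3 and S in compound 4. Among the compounds with values here, no measured pair isolates such a change. With atoms and bonds the same, no shift beyond the scatter is expected in this assay here. The expected change (an at least 1.0-fold lower number from compound 3 to compound 4 (0.00 log units; that floor lies within the scatter)) is small. For compound 4 the estimated solubility is 650 ug/mL with an expected range from 350 ug/mL to 900 ug/mL as a working figure.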

Compound 4, solubility: > 589 ug/mL
Compound 4 ended at the assay's limit; the forecaster's own chance of this, stated with the estimate: 60%; the middle value does not contradict the limit.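

In this assay, within the data shown here, compound 3 and compound 4 both end at limits of the assay, so no step between them can be read. As far as these compounds go, whether the configuration at the saturated ring carbon changes the read-out at all stays open.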